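Shifting a methyl group between amine and tetrazole

This account rests on a few compounds, and the source may have more. Where it says the series, first, only, none or still open, it means among the compounds named here.

Compound 1, `FC(F)(F)c1cc(COC[C@@H](NCc2nn[nH]n2)c2ccccc2)cc(C(F)(F)F)c1`, 23 nM in an assay on CHO cells for displacement of a labelled ligand from Substance-P receptor (Homo sapiens); on this read-out lower numbers stand for stronger inhibition and higher numbers for weaker inhibition
Compound 2, `CN(Cc1nnn(C)n1)[C@H](COCc1cc(C(F)(F)F)cc(C(F)(F)F)c1)c1ccccc1`, 16 nM in this assay

Within the data shown here, only two compounds have been measured in this assay, and they stand within the scatter of each other: a 1.4-fold lower number from compound 1 to compound 2 (0.16 log units; within the scatter), so compound 2 has no measured neighbour that it is separated from beyond the scatter.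

Compound 3 is `Cn1nnnc1CN[C@H](COCc1cc(C(F)(F)F)cc(C(F)(F)F)c1)c1ccccc1`. It differs from compound 2 by ((1-methyl-1H-tetrazol-5-yl)methyl)amino in place of methyl((2-methyl-2H-tetrazol-5-yl)methyl)amino on a saturated chain carbon bound to an aromatic carbon and a saturated chain carbon. Among the measured compounds shown here, the one measured step that bears on this change is a 1.4-fold lower number from compound 1 to compound 2 (0.16 log units; within the scatter), in which a methyl was added both on the amine and on the tetrazole without a shift beyond the scatter. In compound 3 the amine methyl is removed again and the tetrazole methyl sits on a different ring nitrogen. Neither of those two parts of the change has been examined on its own, so there is no basis for expecting a step beyond the scatter in this assay in either direction.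

Compound 3 is therefore estimated at 20 nM, with a range of 7 nM to 60 nM, which means an expected step of a 1.3-fold higher number from compound 2 to compound 3 (0.10 log units; within the scatter).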

Compound 3, half-maximal inhibitory concentration: 10 nM
The estimate for compound 3 lay 2.0-fold (0.30 log units) above the measured number; the measured number falls inside the stated range.
By their numbers in this assay, from the lowest: compounds 3, 2 and 1 (each within the scatter of the next, the first and the last beyond it).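

The change on the tetrazole gives the first separation beyond the scatter in this series: with the amine hydrogen retained, 1-methyl-1H-tetrazol-5-yl in place of 2H-tetrazol-5-yl gives a 2.3-fold lower number from compound 1 to compound 3 (0.36 log units; beyond the scatter) in this assay, a modest step. The step between the two methylated tetrazoles, a 1.6-fold lower number from compound 2 to compound 3 (0.20 log units; within the scatter), stays within the scatter, so this position accepts the ((1-methyl-1H-tetrazol-5-yl)methyl)amino and methyl((2-methyl-2H-tetrazol-5-yl)methyl)amino groups without a separation that can be read. Only compound 1 and compound 3 stand apart in this assay, which shows that a methyl on a ring nitrogen can matter here even without a methyl on the amine, though compound 2 sits within the scatter of both.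

Still open, from the compounds shown here alone, is how the amine methyl and the ring nitrogen carrying the methyl each contribute on their own, which the 2-methyl-2H-tetrazol-5-yl group on an unmethylated amine or the 1-methyl-1H-tetrazol-5-yl group on a methylated amine would address, and whether an ethyl on the ring nitrogen or a carboxylic acid in place of the tetrazole would fit this position. Nothing measured here explains why these numbers fall as they do.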